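A few compounds are considered here, and "the series" means these few. Any claim that something is new, unique, unknown or untested is made for them only; others in the source may bear on it.

Three compounds have been measured in a functional assay on NCI-H292 cells (Homo sapiens) for antiproliferative activity; a higher number here means a weaker inhibitor, a lower number a stronger inhibitor:

Compound 1 `O=C1N/C(=C\c2ccc(O)cc2)C(=O)N1c1ccc(Br)cc1` gives 69900 nM.
Compound 2 `O=C1N/C(=C\c2ccc(O)cc2)C(=O)N1c1cccc(Br)c1` gives only a limit of the assay, > 200000 nM.
Compound 3 `O=C(Nc1ccc(Cl)cc1)c1cccc(N2C(=O)N/C(=C\c3ccc(O)cc3)C2=O)c1` gives 125000 nM.

Compound 1 and compound 2 share the same atoms joined differently: 4-bromophenyl in place of 3-bromophenyl on an amide-type nitrogen in a ring. That change gave an at least 2.8-fold higher number from compound 1 to compound 2 (0.45 log units; beyond the scatter), a step that rests on (the limit of > 200000 nM in this assay, at which 1 of the 3 values shown sits). From compound 2 to compound 3 the change is (4-chlorophenyl)carbamoyl in place of bromo on an aromatic carbon, and it gave an at least 1.6-fold lower number from compound 2 to compound 3 (0.20 log units; that floor lies within the scatter).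

Compound 4 `O=C(Nc1ccc(Cl)cc1)c1ccc(N2C(=O)N/C(=C\c3ccc(O)cc3)C2=O)cc1` is not yet measured. It arises from compound 1 by the same kind of change, ((4-chlorophenyl)carbamoyl in place of bromo on an aromatic carbon); the surroundings differ, since in compound 3 the new group sits meta to a large group, while in compound 4 it sits para to a large group. Because the earlier step of an at least 1.6-fold lower number from compound 2 to compound 3 (0.20 log units; that floor lies within the scatter) is bounded only by a limit, the expectation for compound 4 is loose: a step of about a 1.2-fold lower number from compound 1 to compound 4 (0.07 log units; within the scatter) is expected. Compound 4 is therefore estimated at 60000 nM in this assay, most likely between 20000 nM and 200000 nM.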

Compound 4, half-maximal inhibitory concentration: > 200000 nM
Compound 4: only a limit was reported; the forecaster's own chance of this, stated with the estimate: 25%; middle value at least 3.3-fold (0.52 log units) away from the limit.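

In this assay compound 4 gives only a limit of the assay, > 200000 nM. Placing (4-chlorophenyl)carbamoyl where bromo stood gave an at least 2.8-fold higher number from compound 1 to compound 4 (0.45 log units; beyond the scatter), so this change cannot simply be carried from one core to the other and be expected to act alike: the same change on two cores in this assay, an at least 1.6-fold lower number (0.20 log units; that floor lies within the scatter) from compound 2 to compound 3 and an at least 2.8-fold higher number (0.45 log units; beyond the scatter) from compound 1 to compound 4, at least 4.5-fold (0.66 log units) apart, beyond the scatter of two such steps. The true size of each step remains unknown, and the numbers give no reason for the difference: the limit of > 200000 nM in this assay, at which 2 of the 4 values shown sit.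

The compounds shown leave open how a smaller group in place of bromo, such as a carboxylic acid or an amine, would behave on either core. They also leave open whether the result for compound 4 comes from the whole (4-chlorophenyl)carbamoyl group or only from part of it.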